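Series notes: substituent change at a saturated ring carbon

The compounds below may be only part of what the source reports. "The series", "measured", "known", "first", "only" and "open" are said of these compounds alone.

Measured compounds:
Compound 1 `C=C1C(=O)Oc2cc(OC)ccc2C1C` gives 73000 nM in a functional assay on MCF7 cells (Homo sapiens) for cytotoxicity, read by MTT assay, with a stated time of 48 h; a higher number here means a weaker inhibitor, a lower number a stronger inhibitor.
Compound 2 `C=C1C(=O)Oc2cc(OC)ccc2C1C(C)C` gives 870 nM in this assay.

Compound 1 stands highest of the two numbers; its nearest neighbour is reached by an 84-fold lower number from compound 1 to compound 2 (1.92 log units; beyond the scatter), a large step. Compound 3 `C=CC1C(=C)C(=O)Oc2cc(OC)ccc21` differs from compound 1 by vinyl in place of methyl on a saturated ring carbon. Within the data shown here, only the step from compound 1 to compound 2 bears on this change, and the entering group there was isopropyl rather than vinyl, so a lower number is expected for compound 3 in this assay. The step that this expectation means for compound 3 is estimated as a 9.1-fold lower number from compound 1 to compound 3 (0.96 log units; beyond the scatter), a smaller step than that one. The estimate for compound 3 is 8000 nM, within 2000 nM to 30000 nM.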

Compound 3, half-maximal inhibitory concentration: 62000 nM
Beside the measured number, compound 3's estimate is 7.8-fold (0.89 log units) below it, outside the stated range (above it).
By their numbers in this assay, from the lowest: compound 2; then compounds 3 and 1 (each within the scatter of the next).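

In this assay vinyl in place of methyl on the saturated ring carbon gives no readable change (a 1.2-fold lower number from compound 1 to compound 3 (0.07 log units; within the scatter)), so a larger entering group does not by itself bring the gain seen with isopropyl. Vinyl in place of isopropyl gives a large loss (a 71-fold higher number from compound 2 to compound 3 (1.85 log units; beyond the scatter)), so the outcome at this carbon depends on which group enters. Nothing on hand explains this difference.

Open, on these data alone, is whether ethyl, tert-butyl or cyclopropyl would follow isopropyl or vinyl at this carbon. As far as these compounds go, whether a phenyl ring or an amine is tolerated there also remains open.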